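Swapping 1-hydroxyethyl for 1,3-oxazol-4-yl: a clearance estimate

The compounds below may be only part of what the source reports. "The series", "measured", "known", "first", "only" and "open" are said of these compounds alone.

In an in vivo ADME assay on the whole organism (strain 129/SvEvBrd x C57BL/6) for pharmacokinetics, with Mus musculus as the target, at a dose of 1 mg/kg by the intravenous route (a lower number here means slower removal, a higher number faster removal of the compound), compound 1 `CC(=O)c1nc([C@@H](O)[C@H](O)[C@H](O)CO)c(C)[nH]1` gives 7 mL/min/kg, compound 2 `CC(=O)c1nc([C@@H](O)[C@H](O)[C@H](O)CO)c(-c2ccccc2)[nH]1` gives 23.9 mL/min/kg and compound 3 `CC(O)c1nc([C@@H](O)[C@H](O)[C@H](O)CO)c[nH]1` gives 16.4 mL/min/kg. Compound 3 thus stands within the scatter of compound 2 and beyond it above compound 1. Compound 4 `OC[C@@H](O)[C@@H](O)[C@H](O)c1c[nH]c(-c2cocn2)n1` carries 1,3-oxazol-4-yl in place of 1-hydroxyethyl on an aromatic carbon. For the measured compounds named here, no measured step makes this exchange. The only one that bears on it, even loosely, is a 3.4-fold higher number from compound 1 to compound 2 (0.53 log units; beyond the scatter), a modest rise with phenyl in place of methyl on an aromatic carbon. A slight upward lean is therefore expected, but nothing beyond the scatter. The expected change is a 1.2-fold higher number from compound 3 to compound 4 (0.09 log units; within the scatter). For compound 4 the estimate is 20 mL/min/kg, with an expected range of 8 mL/min/kg to 45 mL/min/kg.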

Compound 4, clearance: 16.6 mL/min/kg
Compound 4: middle estimate off by 1.2-fold (0.08 log units), on the high side; measured number inside the range.
By their numbers in this assay, from the lowest: compound 1; then compounds 3, 4 and 2 (each within the scatter of the next).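

In this assay, putting 1,3-oxazol-4-yl in place of 1-hydroxyethyl, between two ring nitrogen atoms, gives a 1.0-fold higher number from compound 3 to compound 4 (0.01 log units; within the scatter), which lies within the scatter. This place therefore accepts a five-membered aromatic ring instead of an open group, and the loss of the hydrogen-bond donor of 1-hydroxyethyl leaves no readable change in clearance. As far as these compounds go, whether an amine or a carboxylic acid here would also stay within the scatter remains open, as does whether this exchange would read the same with the methyl of compound 1 or the phenyl of compound 2 present. No evidence is available that accounts for this result.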